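Trifluoromethyl for Methyl on the Outer Ring

This account rests on a few compounds, and the source may have more. Where it says the series, first, only, none or still open, it means among the compounds named here.

Measured compounds:
compound 1 `CCCOc1cc(C)c(-c2cccc(COc3ccc(S(=O)(=O)CC(=O)O)cc3)c2)c(C)c1` — 69.2 nM
compound 2 `Cc1cc(OCCCS(C)(=O)=O)cc(C)c1-c1cccc(COc2ccc(S(=O)(=O)CC(=O)O)cc2)c1` — 170 nM
compound 3 `Cc1ccccc1-c1cccc(COc2ccc(S(=O)(=O)CC(=O)O)cc2)c1` — 46.8 nM

In a functional assay on CHO cells for agonist activity at Free fatty acid receptor 1 (Homo sapiens), read by FLIPR and calcium flux (on this read-out higher numbers stand for an effect only at larger amounts of compound and lower numbers for an effect already at smaller amounts), compound 3 gives the lowest number of the three. Compound 1 lies close to it, within the usual scatter, while compound 2 sits further away, beyond the scatter. Going by the values given here, the only step between two measured compounds, a 2.5-fold higher number from compound 1 to compound 2 (0.39 log units; beyond the scatter), concerns a methylsulfonyl added far out on a saturated chain and says nothing about the outer ring that carries the methyl.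

Compound 4 `O=C(O)CS(=O)(=O)c1ccc(OCc2cccc(-c3ccccc3C(F)(F)F)c2)cc1` differs from compound 3 in exactly one place: trifluoromethyl in place of methyl on an aromatic carbon. Among the compounds with values here, no measured pair shows what this exchange does here. With nothing pointing one way or the other, the expectation for this assay is a step that stays within the scatter, in no particular direction, a 1.2-fold higher number from compound 3 to compound 4 (0.07 log units; within the scatter).

Compound 4 is therefore estimated at 55 nM, with a range from 18 nM to 170 nM, an estimate drawn from compound 3 and its value 46.8 nM alone.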

Compound 4, half-maximal effective concentration: 52.5 nM
For compound 4 the middle estimate is 1.0-fold (0.02 log units) above the measured one; measured number inside the range.
By their numbers in this assay, from the lowest: compounds 3, 4 and 1 (each within the scatter of the next); then compound 2.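

On the outer ring, trifluoromethyl in place of methyl on an aromatic carbon, ortho to a large group, brings four heavy atoms where there was one, yet in this assay the result is a 1.1-fold higher number from compound 3 to compound 4 (0.05 log units; within the scatter). Going by these compounds alone, this is the first direct reading at this position, since the earlier step concerned only a methylsulfonyl far out on a saturated chain: here, going from 2-methylphenyl to 2-(trifluoromethyl)phenyl leaves the number where it was, as far as this kind of measurement can tell, so the position accepts this larger group with no shift that can be told from repeat-to-repeat variation. No measurement of any other kind accompanies these numbers, so nothing here explains why the exchange leaves the value unchanged.

Going by these compounds, a single exchange says little about the position as a whole, and how a methoxy group, an amine or a carboxylic acid would fare in the same place remains open. Also open, on these data alone, is whether trifluoromethyl would behave the same way on the outer ring of compound 1, which carries a propoxy group.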